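The source may report more compounds than this note shows. Statements on the series, on what has been measured and on what is new or still open speak of the compounds shown alone.

In a functional assay on A-375 cells (Homo sapiens) for cytotoxicity, read by MTT assay, with a stated time of 48 h (on this read-out lower numbers stand for stronger inhibition and higher numbers for weaker inhibition), compound 1 `CC1(C)S[C@@H]2/C(=C\C(=O)c3ccccc3)C(=O)N2[C@H]1C(=O)OC(c1ccccc1)c1ccccc1` gives 22800 nM, and compound 2 `CC1(C)S[C@@H]2/C(=C\C(=O)c3ccc(F)cc3)C(=O)N2[C@H]1C(=O)OC(c1ccccc1)c1ccccc1` gives 17800 nM; the two numbers lie within the scatter of each other, so neither stands apart. Among the measured compounds shown here, the only measured step, a 1.3-fold lower number from compound 1 to compound 2 (0.11 log units; within the scatter), bears on the move to compound 3 `CC1(C)S[C@@H]2/C(=C\C(=O)c3ccc(Cl)cc3)C(=O)N2[C@H]1C(=O)OC(c1ccccc1)c1ccccc1`, which differs from compound 2 by chloro in place of fluoro on an aromatic carbon. That single step stayed within the scatter, and nothing measured points to a larger shift here. Compound 3 is therefore expected to give 15000 nM in this assay, within 7000 nM to 32000 nM. The expected step is a 1.2-fold lower number from compound 2 to compound 3 (0.07 log units; within the scatter), none beyond the scatter.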

Compound 3, half-maximal inhibitory concentration: 48600 nM
The estimate for compound 3 lay 3.2-fold (0.51 log units) below the measured number; measured number outside the range, above it.
By their numbers in this assay, from the lowest: compounds 2 and 1 (each within the scatter of the next); then compound 3.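

The change at this place, on the aromatic ring and para to a large group, is not neutral in this assay: chloro in place of fluoro gives a 2.7-fold higher number from compound 2 to compound 3 (0.44 log units; beyond the scatter) and chloro in place of hydrogen gives a 2.1-fold higher number from compound 1 to compound 3 (0.33 log units; beyond the scatter). Fluoro had left the number within the scatter of the unsubstituted compound 1, so the two substituents do not behave alike here, and compound 3 is the weakest of the three. Nothing available explains this difference between chloro and fluoro.

From the compounds shown here alone, it remains open whether bromo or methoxy at this place would follow chloro or fluoro. Going by these compounds, how an amine or a carboxylic acid would fare there is equally open.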